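Methyl in place of chloro at the assay limit

The source may report more compounds than this note shows. Statements on the series, on what has been measured and on what is new or still open speak of the compounds shown alone.

Compound 1, `COc1cc(-c2nnc(SCC(=O)c3ccc(Cl)cc3)n2N)cc(OC)c1OC`: > 100000 nM
Compound 2, `COc1cc(-c2nnc(SCC(=O)NCc3ccc(Cl)cc3)n2N)cc(OC)c1OC`: > 100000 nM

Both measured values are limits of the assay rather than numbers. In a functional assay on PC-3 cells (Homo sapiens) for antiproliferative activity, read by MTT assay, with a stated time of 48 h (on this read-out lower numbers stand for stronger inhibition and higher numbers for weaker inhibition), compound 1 gives > 100000 nM, which is a limit. In this assay compound 2 gives > 100000 nM, again a limit. The step that the two limits leave unreadable from compound 1 to compound 2 therefore cannot be read. On the numbers shown, compound 2 stands at the limit, and so does the only other value, as recorded by the limit of > 100000 nM in this assay, at which 2 of the 2 values shown sit.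

Compound 3, `COc1cc(-c2nnc(SCC(=O)NCc3ccc(C)cc3)n2N)cc(OC)c1OC`, is not yet measured. It differs from compound 2 as methyl in place of chloro on an aromatic carbon: the change sits on an aromatic carbon of a six-membered aromatic ring of carbon only, away from the carbonyl and the shared core. Within the data shown here, no measured step bears directly on this change; the one step available, from compound 1 to compound 2, is unreadable because both values sit at the limit of > 100000 nM in this assay, at which 2 of the 2 values shown sit. Nothing in the data points to any step beyond the scatter, so compound 3 is expected to remain at the limit as well, an estimated step that the limit leaves unreadable from compound 2 to compound 3. For compound 3 the expected value in this assay is 120000 nM, with a range from 40000 nM to 400000 nM.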

Compound 3, half-maximal inhibitory concentration: 92800 nM
The estimate for compound 3 lay 1.3-fold (0.11 log units) above the measured number; low and high end bracket the measured number.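

In this assay, among these compounds, compound 3 gives 92800 nM, the only true number among the three values shown, so this position on the aromatic ring now offers a one-sided reading of the swap from chloro to methyl: an at least 1.0-fold lower number from compound 2 to compound 3 (0.03 log units; that floor lies within the scatter). The wider change on the carbonyl carbon, where (4-methylbenzyl)amino takes the place of 4-chlorophenyl, can be read in the same one-sided way: an at least 1.0-fold lower number from compound 1 to compound 3 (0.03 log units; that floor lies within the scatter). Both floors lie within the scatter, so no real gain can be claimed for methyl, and the true size of each step stays unknown because the starting values are limits of the assay: the limit of > 100000 nM in this assay, at which 2 of the 3 values shown sit.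

The compounds shown leave open whether a different group on the same aromatic carbon, such as methoxy, trifluoromethyl or a dimethylamino group, would bring the number clearly beyond the scatter from compound 3. Also open, going by these compounds, is whether a longer chain between the amide nitrogen and the aromatic ring would change the reading, and whether the methyl effect would hold in such a compound.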